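Swapping methylsulfonyl for methyl on an amine nitrogen

The source may hold more compounds than are shown below. What is called first, only, known or untested is meant among the compounds shown, and "the series" means these compounds.

Compound 1 `CC(C)(C)c1cc(C(=O)Nc2nc(CNS(C)(=O)=O)cs2)n(Cc2ccccc2)n1`: 3.1 ug/mL
Compound 2 `NCc1csc(NC(=O)c2ccc(Cl)cc2)n1`: 25 ug/mL
Compound 3 `NCc1csc(NC(=O)c2cc3ccccc3n2Cc2ccccc2)n1`: 1.6 ug/mL

These numbers come from a physicochemical assay for solubility, read by nephelometry, measured as kinetic solubility, at pH 6.5; on this read-out higher numbers stand for higher solubility and lower numbers for lower solubility. Compound 1 sits toward the low end of this small set. Compound 3 lies within the usual scatter of it, while compound 2 stands clearly higher, beyond that scatter.

The next molecule is compound 4 `CNCc1csc(NC(=O)c2cc(C(C)(C)C)nn2Cc2ccccc2)n1`, which has not yet been measured. It keeps the core of compound 1 and makes a single change: methyl in place of methylsulfonyl on an amine nitrogen.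

Among the compounds with values here, no two measured compounds differ in only one place, so nothing here shows directly how large such a change can be. The evidence is indirect and loose. Neither of the other two measured compounds carries the methylsulfonyl, and compound 2 reaches 25 ug/mL. Compound 3, also without that group, gives only 1.6 ug/mL and so goes against any simple rule. A moderate rise in this assay is therefore expected, with wide uncertainty. The expected change is a 2.6-fold higher number from compound 1 to compound 4 (0.41 log units; beyond the scatter). For compound 4 the estimated value is 8 ug/mL, with an expected range from 2.5 ug/mL to 30 ug/mL.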

Compound 4, solubility: 12.5 ug/mL
For compound 4 the middle estimate is 1.6-fold (0.19 log units) below the measured one, and the stated range covers the measured number.
By their numbers in this assay, from the lowest: compounds 3 and 1 (each within the scatter of the next); then compounds 4 and 2 (each within the scatter of the next).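

Within the data shown here, for the first time, a single change can be read directly. In this assay, with the shared core held constant, methyl in place of methylsulfonyl on an amine nitrogen gives a 4.0-fold higher number from compound 1 to compound 4 (0.61 log units; beyond the scatter), so this position does register in the read-out, by a modest step that stands clear of the usual scatter of repeated measurements. No separate measurement bears on the reason for this step, so the number records the size of the change and nothing about how it arises.

This one matched pair leaves open how the same core would behave with a plain primary amine at this position, the form of the nitrogen found in compound 2 and compound 3, or with an acetyl group or a longer chain such as ethyl on that nitrogen, and so whether methyl and methylsulfonyl mark the ends of a wider range or sit inside it. It also leaves open whether a step of similar size would appear on a different core, as a single pair on one core cannot show how far this change carries.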